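The source may report more compounds than this note shows. Statements on the series, on what has been measured and on what is new or still open speak of the compounds shown alone.

The measured compounds and their values in a functional assay on HCT-116 cells (Homo sapiens) for cytotoxicity, read by MTT assay, with a stated time of 72 h; on this read-out higher numbers stand for weaker inhibition and lower numbers for stronger inhibition:

Compound 1, `O=C(NCc1ccc(F)cc1)c1nc(Br)c2cccnc2c1NCc1ccccc1`, gives > 20000 nM; this is a limit of the assay, not a number.
Compound 2, `CS(=O)(=O)Oc1c(C(=O)NCc2ccc(F)cc2)nc(Br)c2cccnc12`, gives > 20000 nM; this too is a limit.
Compound 3, `NCCCNc1c(C(=O)NCc2ccc(F)cc2)nc(Br)c2cccnc12`, gives 18000 nM.

For the measured compounds named here, compound 3 therefore holds the only actual number among the three; the other two results sit at the limit of > 20000 nM in this assay, at which 2 of the 3 values shown sit. Compound 4, `Nc1cccc(Nc2c(C(=O)NCc3ccc(F)cc3)nc(Br)c3cccnc23)c1`, is not yet measured. It differs from compound 3 in one place: 3-aminophenyl in place of 3-aminopropyl on a nitrogen on an aromatic ring. One six-membered aromatic ring of carbon only enters where no ring was, while the count of hydrogen-bond donors and acceptors stays the same.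

Going by the values given here, two measured steps bear on this. The step of an at least 1.1-fold lower number from compound 1 to compound 3 (0.04 log units; that floor lies within the scatter) swapped 2-aminoethyl for phenyl on a saturated chain carbon bound to a nitrogen on an aromatic ring, and the step of an at least 1.1-fold lower number from compound 2 to compound 3 (0.04 log units; that floor lies within the scatter) put (3-aminopropyl)amino in place of (methylsulfonyl)oxy; both are floors that lie within the scatter. Nothing here points beyond weak inhibition, and a phenyl-bearing compound 1 sat at a limit. Compound 4 is expected to give about 20000 nM, between 7000 nM and 50000 nM. The expected step is a 1.1-fold higher number from compound 3 to compound 4 (0.05 log units; within the scatter), likely ending again at a limit.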

Compound 4, half-maximal inhibitory concentration: > 10000 nM
Compound 4: a limit, no number (the forecaster's own chance of this, stated with the estimate: 60%); the middle value does not contradict the limit.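

Compound 4 gives > 10000 nM, which is a limit of the assay and not a number, so its steps from compound 1, compound 2 and compound 3 cannot be read. The compounds shown leave open whether 3-aminophenyl in place of 3-aminopropyl changes the inhibition at all.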